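The compounds below may be only part of what the source reports. "The series", "measured", "known", "first", "only" and "open" are said of these compounds alone.

Compound 1, `CC(C)NC1=NS(=O)(=O)c2cc(Cl)c(Cl)cc2N1`, is the reference point of this small set. In a functional assay (aorta) with Rattus norvegicus as the target, with a stated time of 90 min, at 37 degrees C (a lower number here means that less compound is needed, a higher number that more compound is needed for the effect), compound 1 gives 2300 nM. Compound 3, `CC(C)NC1=NS(=O)(=O)c2cc(Br)c(Cl)cc2N1`, differs from it in one place: bromo in place of chloro on an aromatic carbon. This change led to a 2.4-fold higher number from compound 1 to compound 3 (0.39 log units; beyond the scatter), so in this assay compound 3 gives 5600 nM.

Compound 2, `O=S1(=O)NC(NC2CCC2)=Nc2cc(Cl)c(Cl)cc21`, carries a different substituent on the exocyclic nitrogen; the difference between its core and the core of compound 1 is not broken down here. In this assay compound 2 gives 12600 nM, the highest of the three numbers obtained so far, and its value lies beyond the scatter of both compound 1 and compound 3.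

Compound 4, `O=S1(=O)NC(NC2CCC2)=Nc2cc(Cl)c(Br)cc21`, has not yet been measured. It relates to compound 2 as compound 3 relates to compound 1: bromo in place of chloro on an aromatic carbon. The surroundings of the exchanged group are described in the same words in both pairs, so the change is the same one, applied to a different core. For the measured compounds named here, the only guide to its effect is the measured pair, in which compound 1 moved to compound 3 by a 2.4-fold higher number from compound 1 to compound 3 (0.39 log units; beyond the scatter). On that basis compound 4 is expected to give a step of about a 2.4-fold higher number from compound 2 to compound 4 (0.38 log units; beyond the scatter) from compound 2. Going by the values given here, for compound 4 in this assay the estimate is 30000 nM, with a plausible range from 14000 nM to 70000 nM, resting on the single measured step from compound 1 to compound 3 and on the value of compound 2, 12600 nM.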

Compound 4, half-maximal effective concentration: 6600 nM
For compound 4 the middle estimate is 4.5-fold (0.66 log units) above the measured one, outside the stated range (below it).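

In this assay, bromo in place of chloro on an aromatic carbon did not give the same result on the two cores: the same change on two cores in this assay, a 2.4-fold higher number (0.39 log units; beyond the scatter) from compound 1 to compound 3 and a 1.9-fold lower number (0.28 log units; within the scatter) from compound 2 to compound 4, 4.6-fold (0.67 log units) apart, beyond the scatter of two such steps. On the core of compound 2 the change gives a 1.9-fold lower number from compound 2 to compound 4 (0.28 log units; within the scatter), so the two compounds cannot be told apart here, whereas on the core of compound 1 the step is a 2.4-fold higher number from compound 1 to compound 3 (0.39 log units; beyond the scatter). For the compounds shown here, this shows that, in this series, the step measured on one core cannot simply be carried over to another, but with only one pair on each core it does not show what in the cores sets the two steps apart, nor how either step would behave on a third core.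

The compounds shown leave open whether fluoro or iodo on the same aromatic carbon would follow the pattern of the pair on the core of compound 1 or that of the pair on the core of compound 2. They also leave open how the exchange of chloro for bromo would fare with a longer chain or an open-chain amine on the exocyclic nitrogen.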